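The compounds below may be only part of what the source reports. "The series", "measured", "known", "first", "only" and "open" are said of these compounds alone.

Measured compounds:
- compound 1, `COc1nc(-c2nc3ccccc3n2C)cc(-c2ccc(F)cc2)c1C#N`: 343000 nM
- compound 2, `CCOc1nc(-c2nc3ccccc3n2C)cc(-c2ccc(F)cc2)c1C#N`: 362000 nM
- compound 3, `COc1ccc(-c2cc(-c3nc4ccccc4n3C)nc(OC)c2C#N)cc1`: 210000 nM

All three numbers come from a functional assay on aorta (Rattus norvegicus, strain Wister); a lower number here means a stronger inhibitor, a higher number a weaker inhibitor. Compound 2 gives the highest number of the three, but its nearest neighbour is compound 1 at a 1.1-fold higher number from compound 1 to compound 2 (0.02 log units; within the scatter), and its gap to compound 3 is also within the scatter, so the three compounds cannot be separated on these data.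

Compound 4, `CCOc1nc(-c2nc3ccccc3n2C)cc(-c2cccs2)c1C#N`, has not yet been measured. It differs from compound 2 by thiophen-2-yl in place of 4-fluorophenyl on an aromatic carbon. Among the compounds with values here, the only measured step that touches this position is a 1.6-fold lower number from compound 1 to compound 3 (0.21 log units; within the scatter), which swapped a substituent on the six-membered ring without effect beyond the scatter. The step of a 1.1-fold higher number from compound 1 to compound 2 (0.02 log units; within the scatter) concerns the ethoxy group and does not bear on the change. Within the data shown here, no measured step replaces the whole 4-fluorophenyl by a five-membered ring, so the expectation rests on the flatness seen so far.

Compound 4 is therefore expected to stay close to compound 2, with an estimated step of a 1.0-fold lower number from compound 2 to compound 4 (0.01 log units; within the scatter). The estimate for compound 4 in this assay is 350000 nM, expected between 140000 nM and 900000 nM.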

Compound 4, half-maximal inhibitory concentration: 249000 nM
Beside the measured number, compound 4's estimate is 1.4-fold (0.15 log units) above it; low and high end bracket the measured number.
By their numbers in this assay, from the lowest: compounds 3, 4, 1 and 2 (each within the scatter of the next).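

In this assay the exchange of 4-fluorophenyl for thiophen-2-yl gives a 1.5-fold lower number from compound 2 to compound 4 (0.16 log units; within the scatter) and so extends the flat picture at this position. The earlier step from compound 1 to compound 3 changed only a substituent on the six-membered ring, whereas here the whole ring gives way to a five-membered aromatic ring with a sulfur atom and the number stays within the scatter. Nothing shown accounts for this flatness or tells whether the group at this position matters at all.

All four compounds still lie within the scatter of their neighbours, so no group here separates from the rest. Open, on these data alone, is whether an amine or a carboxylic acid at this position, or a longer chain in place of the ethoxy group, would move the number beyond the scatter.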